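This account rests on a few compounds, and the source may have more. Where it says the series, first, only, none or still open, it means among the compounds named here.

Compound 1, `CNCC(=O)Nc1cc(OC)ccc1C(=O)c1ccc2c(c1)C=CC(C)(C)O2`, gives 800 nM in a functional assay on A549 cells (Homo sapiens) for antiproliferative activity, read by MTT assay, with a stated time of 48 h; a higher number here means a weaker inhibitor, a lower number a stronger inhibitor. Compound 2, `COc1ccc(C(=O)c2ccc3c(c2)C=CC(C)(C)O3)c(NC(=O)CN(C)C)c1`, gives 1160 nM in this assay, so that the step of a 1.5-fold higher number from compound 1 to compound 2 (0.16 log units; within the scatter) is made by methyl in place of hydrogen on an amine nitrogen. Compound 3, `C=C(c1cc(OC)c(OC)c(OC)c1)c1ccc(OC)cc1NC(=O)CN`, gives 40 nM in this assay; the difference between its core and the core of compound 1 is not broken down here. Compound 4, `C=C(c1cc(OC)c(OC)c(OC)c1)c1ccc(OC)cc1NC(=O)CNC`, is not yet measured and differs from compound 3 by methyl in place of hydrogen on an amine nitrogen. This is the same kind of change as that between compound 1 and compound 2, though there the amine nitrogen carried two saturated chain carbons beside the new methyl, while in compound 4 it carries one. Because a 1.5-fold higher number from compound 1 to compound 2 (0.16 log units; within the scatter) stays within the scatter, the step expected here is a 1.4-fold higher number from compound 3 to compound 4 (0.14 log units; within the scatter), and compound 4 is estimated to give 55 nM in this assay, with a range of 25 nM to 120 nM.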

Compound 4, half-maximal inhibitory concentration: 100 nM
Beside the measured number, compound 4's estimate is 1.8-fold (0.26 log units) below it; measured number inside the range.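

In this assay, methyl in place of hydrogen on an amine nitrogen gives a 2.5-fold higher number from compound 3 to compound 4 (0.40 log units; beyond the scatter), and this step does not separate from the earlier one: the same change on two cores in this assay, a 1.5-fold higher number (0.16 log units; within the scatter) from compound 1 to compound 2 and a 2.5-fold higher number (0.40 log units; beyond the scatter) from compound 3 to compound 4, 1.7-fold (0.24 log units) apart, within the scatter of two such steps. As far as this single pair of steps can tell, the size of the step carries from one core to the other. Within the data shown here, it does not show a rule for other cores, and it does not settle whether the two steps are truly equal, since only the step on the core of compound 3 lies beyond the scatter.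

Left open is how a dimethylamino group would read on the core of compound 3. Also open, from the compounds shown here alone, is how an ethyl group or a longer chain on that nitrogen would read there.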